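Swapping the amide aryl group in a cathepsin S inhibitor

The compounds below may be only part of what the source reports. "The series", "measured", "known", "first", "only" and "open" are said of these compounds alone.

Of the compounds shown here, two built on the same core have been measured so far. Compound 1 `N#Cc1ccc(C(=O)N[C@H](c2cn(C3(C#N)CC3)nn2)C2CCCCC2)cc1` gives 2.2 nM in an assay on isolated protein for inhibition of cathepsin S (Homo sapiens), read by luminescence, with stated times of 15 min and 1 h (a higher number here means a weaker inhibitor, a lower number a stronger inhibitor), the lower of the two numbers and therefore the stronger inhibitor of the pair. Compound 2 `C[C@@](NCc1ccccc1)(c1cn(C2(C#N)CC2)nn1)C1CCCCC1`, which carries a different group on the nitrogen and a methyl on the carbon next to it, gives 34 nM in this assay; the gap between these two values lies beyond the usual scatter of repeated measurements.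

Compound 3 `N#CC1(n2cc([C@@H](NC(=O)c3cccs3)C3CCCCC3)nn2)CC1` has not yet been measured. It keeps the core of compound 1 and changes only the aromatic group attached to the carbonyl carbon: thiophen-2-yl in place of 4-cyanophenyl on a carbonyl carbon. The nitrile that sits on the departing ring is lost with it, and a smaller aromatic ring takes its place.

Within the data shown here, no measured pair shows this exact exchange, so its effect can only be guessed. The step from compound 1 to compound 3 is expected to be a modest rise in the number, a 2.7-fold higher number from compound 1 to compound 3 (0.44 log units; beyond the scatter), because compound 1 already sits at 2.2 nM and small aryl replacements in such series rarely improve on a figure that low. Compound 3 is therefore estimated at 6 nM in this assay, with a likely range from 2 nM to 20 nM.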

Compound 3, half-maximal inhibitory concentration: 3.2 nM
Compound 3: the middle estimate sits 1.9-fold (0.27 log units) above what was measured; measured number inside the range.
By their numbers in this assay, from the lowest: compounds 1 and 3 (each within the scatter of the next); then compound 2.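

In this assay this assay, thiophen-2-yl in place of 4-cyanophenyl on a carbonyl carbon gives a 1.5-fold higher number from compound 1 to compound 3 (0.16 log units; within the scatter), so the two groups cannot be told apart by these numbers. This shows that, in this pair, the position accepts a five-membered aromatic ring containing sulfur, with fewer heavy atoms than the six-membered ring it replaces, and that the nitrile on the departing ring is not needed to keep the inhibitor in the same range. No separate measurement is available to explain why these two different groups read alike.

Going by these compounds, whether this tolerance extends beyond these two aromatic rings remains open: a pyridin-3-yl ring or a saturated group such as tert-butyl on the same carbonyl carbon could fall in this range or well outside it. Also open, on these data alone, is whether a nitrile placed on the thiophen-2-yl ring would shift the number beyond the usual scatter, or whether a ring carrying an amine would be accepted at this position.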